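The source may hold more compounds than are shown below. What is called first, only, known or untested is meant among the compounds shown, and "the series" means these compounds.

Working notes on the series: compound 1 `COc1cccc(/C=C2\CCC/C(=C\c3ccccc3Cl)C2=O)c1OC`, compound 2 `COc1cccc(/C=C2\CCC/C(=C\c3cccc(Br)c3)C2=O)c1OC`, compound 3 `COc1cccc(/C=C2\CCC/C(=C\c3ccc(O)cc3)C2=O)c1OC` and the unmeasured compound 4 `COc1cccc(/C=C2\CCC/C(=C\c3ccc(Cl)c(Cl)c3)C2=O)c1OC` share one core. In a functional assay on HT-1080 cells (Homo sapiens) for cytotoxicity, read by MTT assay, with a stated time of 72 h (on this read-out higher numbers stand for weaker inhibition and lower numbers for stronger inhibition), compound 1 gives 11700 nM and compound 2 gives 12200 nM, and a 1.0-fold higher number from compound 1 to compound 2 (0.02 log units; within the scatter) leaves the pair together.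

Compound 3 reads > 20000 nM, which is a limit of this assay and not a number. The steps to it are an at least 1.7-fold higher number from compound 1 to compound 3 (0.23 log units; that floor lies within the scatter) and an at least 1.6-fold higher number from compound 2 to compound 3 (0.21 log units; that floor lies within the scatter). As far as these compounds go, both are floors within the scatter, so its true distance from the other two remains open.

The next change puts 3,4-dichlorophenyl in place of 4-hydroxyphenyl on a double-bonded chain carbon bound to a double-bonded ring carbon. Among the compounds with values here, the two steps to compound 3 bear on this change in reverse, while a 1.0-fold higher number from compound 1 to compound 2 (0.02 log units; within the scatter) is the only comparison between two measured halogen-bearing rings. Within the data shown here, no measured compound carries two chlorines on this ring, so the expectation rests on the nearest measured analogues, compound 1 at 11700 nM and compound 2 at 12200 nM. A lower number than the limit of compound 3 is expected in this assay, though the step may be modest.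

The estimated step is an at least 2.0-fold lower number from compound 3 to compound 4 (0.30 log units; that floor lies within the scatter).

For compound 4, the expected value is 10000 nM, with an estimated range of 5000 nM to 20000 nM.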

Compound 4, half-maximal inhibitory concentration: 10800 nM
Compound 4: middle estimate off by 1.1-fold (0.03 log units), on the low side; the range from low to high includes it.
By their numbers in this assay, from the lowest: compounds 4, 1 and 2 (each within the scatter of the next). At a limit, above all of these: compound 3.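

In this assay, putting 3,4-dichlorophenyl in place of 4-hydroxyphenyl on a double-bonded chain carbon bound to a double-bonded ring carbon gives an at least 1.8-fold lower number from compound 3 to compound 4 (0.26 log units; that floor lies within the scatter), so this change is not shown to go beyond the scatter. A second chlorine on the ring brings no readable separation from the rings with one halogen, with a 1.1-fold lower number from compound 2 to compound 4 (0.05 log units; within the scatter) and a 1.1-fold lower number from compound 1 to compound 4 (0.03 log units; within the scatter), and so three different halogen patterns at this place stand together. Compound 3 remains a limit and not a number, which leaves the true size of its steps unknown: the limit of > 20000 nM in this assay, at which 1 of the 4 values shown sits.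

The compounds shown leave open whether any ring at this place can bring the number clearly below the level of the halogen-bearing rings, and whether the gap to compound 3, if real, is tied to the hydroxyl itself. A plain phenyl, or a ring carrying an amine or a carboxylic acid in place of the hydroxyl, would bear on both questions.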